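Pyridinyl ether swap in a dichloropyridine amide series

The source may report more compounds than this note shows. Statements on the series, on what has been measured and on what is new or still open speak of the compounds shown alone.

Measured compounds:
compound 1 `Cc1ccnc(OC(c2ccc(C(F)(F)F)cc2)C2CCN(C(C)CCNC(=O)c3c(Cl)cncc3Cl)CC2)c1`, 33600 nM
compound 2 `CC(CCNC(=O)c1c(Cl)cncc1Cl)N1CCC(C2(c3ccc(C(F)(F)F)cc3)Cc3ccccc3O2)CC1`, 33800 nM

In an ADME assay on PBMC cells (Homo sapiens) for cytotoxicity (on this read-out lower numbers stand for higher toxicity in this test and higher numbers for lower toxicity in this test), compound 1 gives 33600 nM. Compound 2 gives 33800 nM in this assay, which is within the scatter of compound 1, so the two numbers show no difference. Compound 1 thus stands at the lowest of the two numbers, but only nominally.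

Compound 3 `COC(=O)c1cccc(OC(c2ccc(C(F)(F)F)cc2)C2CCN(C(C)CCNC(=O)c3c(Cl)cncc3Cl)CC2)n1` has not been measured. It differs from compound 1 in one place: 6-(methoxycarbonyl)pyridin-2-yl in place of 4-methylpyridin-2-yl on an oxygen on a saturated carbon. Within the data shown here, no step between two measured compounds isolates this change, so nothing in the two measured numbers speaks to it. With the shared core unchanged and both measured compounds sitting at the same level, the step from compound 1 to compound 3 in this assay is expected to be none beyond the scatter, a 1.1-fold lower number from compound 1 to compound 3 (0.05 log units; within the scatter). Compound 3 is estimated at 30000 nM, with a range from 12000 nM to 65000 nM.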

Compound 3, half-maximal cytotoxic concentration: 14600 nM
Compound 3: the middle estimate sits 2.1-fold (0.31 log units) above what was measured; low and high end bracket the measured number.
By their numbers in this assay, from the lowest: compound 3; then compounds 1 and 2 (each within the scatter of the next).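

At the place on an oxygen on a saturated carbon, the pyridine substituent is not neutral in this assay: 6-(methoxycarbonyl)pyridin-2-yl in place of 4-methylpyridin-2-yl gives a 2.3-fold lower number from compound 1 to compound 3 (0.36 log units; beyond the scatter), the only step shown that isolates one change. The step is modest, but it points towards higher toxicity in this test, so this place can shift the read-out. No measurement at hand bears on why the number falls.

Among these compounds, the single step does not separate the effect of adding methoxycarbonyl from that of losing the methyl group, since the two change together along with the substituent's place on the ring. On these data alone, it also remains open whether a carboxylic acid in place of the methoxycarbonyl group would keep, enlarge or reverse the step.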